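An added three-membered ring on a low-clearance compound

This account rests on a few compounds, and the source may have more. Where it says the series, first, only, none or still open, it means among the compounds named here.

In an ADME assay on microsomes from liver (Homo sapiens) for metabolic stability, read by LC-MS, using NADPH, with stated times of 5 min and 30 min, tested at 1 uM (on this read-out lower numbers stand for slow clearance and higher numbers for fast clearance), compound 1 `CN(C(=O)c1ccccc1)c1cnc(NCc2c(F)ccc3c2CCO3)n2cnnc12` reads > 300 mL.min-1.g-1, which is a limit of the assay. Compound 2 `O=C(Nc1cnc(NCc2c(F)ccc3c2CCO3)n2cnnc12)c1ccccc1` gives 10 mL.min-1.g-1. Compound 3 `C[C@H]1CC(=O)N(c2cnc(NCc3c(F)ccc4c3CCO4)n3cnnc23)C1` reads < 3 mL.min-1.g-1, which is also a limit. Its steps from both other compounds lie beyond the scatter, so it stands lowest of the three.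

Compound 4 `O=C1CC2(CC2)CN1c1cnc(NCc2c(F)ccc3c2CCO3)n2cnnc12` differs from compound 3 by a group of 8 heavy atoms (6 carbon, 1 nitrogen, 1 oxygen; one three-membered non-aromatic ring of carbon only, one five-membered non-aromatic ring with 1 hetero atom) in place of a group of 7 heavy atoms (5 carbon, 1 nitrogen, 1 oxygen; one five-membered non-aromatic ring with 1 hetero atom), on an aromatic carbon. The one five-membered non-aromatic ring with 1 hetero atom stays, and one three-membered non-aromatic ring of carbon only enters.

Two measured steps changed the same aromatic carbon: the large at least 100-fold lower number from compound 1 to compound 3 (2.00 log units; beyond the scatter) and the at least modest an at least 3.3-fold lower number from compound 2 to compound 3 (0.52 log units; beyond the scatter). Both removed a whole benzoyl-bearing group, which is a far bigger exchange than this one. Measured against the smaller of those, an at least 3.3-fold lower number from compound 2 to compound 3 (0.52 log units; beyond the scatter), only a small rise or no change beyond the scatter is expected in this assay. The expected change is an at least 1.6-fold higher number from compound 3 to compound 4 (0.22 log units; that floor lies within the scatter). Compound 4 is estimated at 5 mL.min-1.g-1, with an expected range from 2 mL.min-1.g-1 to 15 mL.min-1.g-1.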

Compound 4, intrinsic clearance in microsomes in the Homo sapiens assay: < 3 mL.min-1.g-1
Compound 4: no number, only a limit (the forecaster's own chance of this, stated with the estimate: 35%); at least 1.6-fold (0.22 log units) between middle value and limit.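

In the Homo sapiens assay compound 4 gives < 3 mL.min-1.g-1, which is a limit and no number. In the Homo sapiens assay compound 3 gives < 3 mL.min-1.g-1, which is also a limit. So this position takes the added three-membered ring without leaving that limit, and the step between the two cannot be read: the limit of < 3 mL.min-1.g-1 in the Homo sapiens assay, at which 2 of the 4 values shown sit.

In the Homo sapiens assay the ring-bearing lactam keeps the whole distance from the benzoyl-bearing compounds, with an at least 3.3-fold lower number from compound 2 to compound 4 (0.52 log units; beyond the scatter) and an at least 100-fold lower number from compound 1 to compound 4 (2.00 log units; beyond the scatter).

In a physicochemical assay for lipophilicity, using the shake flask method, in phosphate buffer, measured as octanol-water partition, with a stated time of 30 min, at pH 7.4 (on this read-out higher numbers stand for higher lipophilicity and lower numbers for lower lipophilicity), compound 3 gives 1.8 and compound 4 gives 1.9. In the physicochemical assay the same exchange gives a number 0.10 log units higher from compound 3 to compound 4 (within the scatter), so the added ring brings no change there beyond the scatter.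

As far as these compounds go, how compound 3 and compound 4 rank in clearance stays open, since neither has a number in that assay. Also open, from the compounds shown here alone, is whether a hydroxyl group or a primary amine on the five-membered ring, in place of the three-membered ring, would stay at the same limit.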